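Moving a Methoxy Group on an Anilino Ring

The compounds below may be only part of what the source reports. "The series", "measured", "known", "first", "only" and "open" are said of these compounds alone.

Measured so far:
- compound 1 `COc1ccc(C(F)(F)F)cc1Nc1ncc(C(F)(F)F)c(N2Cc3cccc(N(C)S(C)(=O)=O)c3C2)n1`: 17200 nM
- compound 2 `CC(=O)N1CCN(c2ccc(Nc3ncc(C(F)(F)F)c(N4Cc5cccc(N(C)S(C)(=O)=O)c5C4)n3)cc2)CC1`: 730 nM

Both compounds were tested in a functional assay on HeLa cells (Homo sapiens) for antiproliferative activity, read by spectrophotometry, with a stated time of 2 days; a higher number here means a weaker inhibitor of growth, a lower number a stronger inhibitor of growth. Compound 1 gives 17200 nM, the higher of the two numbers, so of the two it is the weaker inhibitor of growth. Its nearest neighbour is compound 2, which gives 730 nM, a much lower number, and the gap between them is well beyond the scatter of repeated measurements. For the measured compounds named here, no single-change step between these two measured compounds is available, since they differ in several places at once.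

Compound 3 `COc1cc(Nc2ncc(C(F)(F)F)c(N3Cc4cccc(N(C)S(C)(=O)=O)c4C3)n2)cc(C(F)(F)F)c1` has not yet been measured. It is built from the same atoms as compound 1, joined differently: 3-methoxy-5-(trifluoromethyl)phenyl in place of 2-methoxy-5-(trifluoromethyl)phenyl on a nitrogen on an aromatic ring. The methoxy group is moved to another position on the same ring, while the trifluoromethyl group and the rest of the shared core stay as they are.

Nothing in the measured pair shows how this rearrangement will play out, so the step from compound 1 to compound 3 in this assay is expected to be small, a 1.7-fold lower number from compound 1 to compound 3 (0.24 log units; within the scatter), possibly not beyond the scatter in either direction. Compound 3 is estimated to give 10000 nM, within a range from 2000 nM to 50000 nM.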

Compound 3, concentration for 50% growth inhibition: 5100 nM
Compound 3: middle estimate off by 2.0-fold (0.29 log units), on the high side, within the range that was stated.
By their numbers in this assay, from the lowest: compound 2; then compound 3; then compound 1.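

In this assay, for the compounds shown here, putting 3-methoxy-5-(trifluoromethyl)phenyl in place of 2-methoxy-5-(trifluoromethyl)phenyl on a nitrogen on an aromatic ring gives a 3.4-fold lower number from compound 1 to compound 3 (0.53 log units; beyond the scatter) and is the first single-change comparison in this set. The step is modest but beyond the scatter, and the two compounds hold the same atoms, joined differently, so the arrangement of groups on this ring alone is enough to change the growth-inhibition number. Nothing available explains why the number moves in this direction.

As far as these compounds go, a single pair cannot show how much of the step depends on the methoxy group itself, so it remains open whether a hydroxyl group, an ethoxy group or an amine in its place on the 3-methoxy-5-(trifluoromethyl)phenyl ring would give a lower or a higher number. From the compounds shown here alone, it also remains open whether the same rearrangement would produce a step of similar size with the trifluoromethyl group replaced by a nitrile, or in cells other than the ones used here.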